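The compounds below may be only part of what the source reports. "The series", "measured", "known", "first", "only" and "open" are said of these compounds alone.

Measured compounds:

compound 1, `Cc1ccc(Oc2ccc(/C=N/NC(=S)Nc3ccccc3)cc2)cc1`: 5.39 in a physicochemical assay for lipophilicity, in phosphate buffer, measured as octanol-water partition, with a stated time of 24 h; a lower number here means a more polar compound, a higher number a more lipophilic compound
compound 2, `S=C(N/N=C/c1ccc(Oc2ccc(Br)cc2)cc1)Nc1ccccc1`: 5.62 in this assay
compound 3, `Cc1ccc(Oc2ccc(/C=N/NC(=S)Nc3ccc(Cl)cc3)cc2)cc1`: 5.97 in this assay

Compound 3 gives the highest of the three numbers in this assay; the gap to compound 2 and the gap to compound 1 are both beyond the scatter, so compound 3 is the most lipophilic of the measured set. Compound 1 and compound 2 lie within the scatter of each other, so no order is read between them.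

Compound 4, `S=C(N/N=C/c1ccc(Oc2ccc(Br)cc2)cc1)Nc1ccc(Cl)cc1`, has not yet been measured in this assay. It differs from compound 3 by bromo in place of methyl on an aromatic carbon. The same change, at the same place, is already on record once among the measured compounds: from compound 1 to compound 2, where it gave a number 0.23 log units higher from compound 1 to compound 2 (within the scatter). The cores on which the change is made are not the same: compound 3 differs from compound 1 by chloro in place of hydrogen on an aromatic carbon, and that difference on its own gave a number 0.58 log units higher from compound 1 to compound 3 (beyond the scatter).

Among the measured compounds shown here, only one earlier instance of the change exists, on a core without the chloro group, so the transfer to the core of compound 3 rests on that single step. From compound 3 to compound 4 a step of about a number 0.23 log units higher from compound 3 to compound 4 (within the scatter) is expected in this assay, because the same change gave a number 0.23 log units higher from compound 1 to compound 2 (within the scatter). Compound 4 is therefore estimated at 6.2 in this assay. The range from 5.85 to 6.55 is expected to hold the measured number for compound 4.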

Compound 4, partition coefficient: 6.37
Compound 4: middle estimate off by 0.17 log units, on the low side, within the range that was stated.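

In this assay the change from 4-methylphenoxy to 4-bromophenoxy now stands on two cores: the core of compound 1 gave a number 0.23 log units higher from compound 1 to compound 2 (within the scatter) and the core of compound 3, which carries the chloro group, gave a number 0.40 log units higher from compound 3 to compound 4 (beyond the scatter) as its second instance, so only the second step can be read on its own as a real difference. The chloro in place of hydrogen change can also be read on both cores, as a number 0.58 log units higher from compound 1 to compound 3 (beyond the scatter) and as a number 0.75 log units higher from compound 2 to compound 4 (beyond the scatter) on the bromo core, and there the direction holds across the four compounds, though two instances of each change do not fix a size for either step or show that it would carry to any further core. Nothing on hand bears on why these steps take the sizes they do.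

On these data alone, all four compounds keep the same thiosemicarbazone-free reading of the shared core and vary only methyl, bromo, hydrogen and chloro, so how these steps would read beside a more polar group remains open. An amine or a carboxylic acid in place of the bromo, or a longer chain in place of the methyl, would test whether the change carries beyond this narrow set.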